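The compounds below may be only part of what the source reports. "The series", "measured", "known", "first", "only" and "open" are said of these compounds alone.

Compound 1 `O=C(N/N=C/c1cccc(Br)c1)Nc1ccc(Oc2ccnc3[nH]ccc23)c(F)c1` gives 4020 nM
Compound 2 `O=C(N/N=C/c1ccc(F)cc1)Nc1ccc(Oc2ccnc3[nH]ccc23)c(F)c1` gives 2330 nM
Compound 3 `O=C(N/N=C/c1ccc([N+](=O)[O-])cc1)Nc1ccc(Oc2ccnc3[nH]ccc23)c(F)c1` gives 150 nM

These values come from a functional assay on PC-3 cells (Homo sapiens) for antiproliferative activity, read by MTT assay, with a stated time of 72 h (a lower number here means a stronger inhibitor, a higher number a weaker inhibitor), and compound 3 has the lowest of the three numbers. Compound 4 `O=C(N/N=C/c1cccc(Cl)c1Cl)Nc1ccc(Oc2ccnc3[nH]ccc23)c(F)c1` carries 2,3-dichlorophenyl in place of 4-nitrophenyl on a carbon with a double bond to nitrogen. Two large measured steps end at the 4-nitrophenyl compound (a 27-fold lower number from compound 1 to compound 3 (1.43 log units; beyond the scatter)) (a 16-fold lower number from compound 2 to compound 3 (1.19 log units; beyond the scatter)) while the step between the other two lies within the scatter (a 1.7-fold lower number from compound 1 to compound 2 (0.24 log units; within the scatter)). Within the data shown here, a large rise in the number is therefore expected, towards compound 1 and compound 2, although no compound with two chlorines has been measured. The expected change is a rise (a 19-fold higher number from compound 3 to compound 4 (1.27 log units; beyond the scatter)). Compound 4 is estimated at 2800 nM with an expected range from 900 nM to 8000 nM in this assay.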

Compound 4, half-maximal inhibitory concentration: "not active" (no number reported)
No number was reported for compound 4; no gap can be computed for the estimate.
By their numbers in this assay, from the lowest: compound 3; then compounds 2 and 1 (each within the scatter of the next).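

Among these compounds, compound 4 is reported as "not active" without a number in this assay, so no step from compound 3 to compound 4 can be read. The compounds shown leave open where compound 4 stands numerically against compounds 1, 2 and 3. No measurement here accounts for this result.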